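Benzothiazolone for benzoxazinone on a triazole-linked biphenyl scaffold

A few compounds are considered here, and "the series" means these few. Any claim that something is new, unique, unknown or untested is made for them only; others in the source may bear on it.

Compound 1, `O=C1COc2ccc(-n3cc(C[C@H](O)COCCOC[C@@H](O)Cc4ccc(-c5ccccc5)cc4)nn3)cc2N1`: 15200 nM
Compound 2, `COC1=C(OC)C(=O)C(CCCCCCCCCCCCCCCn2cc(C[C@H](O)COCCOC[C@@H](O)Cc3ccc(-c4ccccc4)cc3)nn2)=C(C)C1=O`: 2490 nM

In a functional assay on SGC-7901 cells (Homo sapiens) for inhibition, read by MTT assay, with a stated time of 72 h (on this read-out higher numbers stand for weaker inhibition of growth and lower numbers for stronger inhibition of growth), compound 1 gives 15200 nM, the highest of the two numbers; compound 2 gives 2490 nM, a gap beyond the usual scatter. Compound 3, `O=c1[nH]c2ccc(-n3cc(C[C@H](O)COCCOC[C@@H](O)Cc4ccc(-c5ccccc5)cc4)nn3)cc2s1`, has not been measured. It differs from compound 1 by a group of 10 heavy atoms (7 carbon, 1 nitrogen, 1 oxygen, 1 sulfur; one five-membered aromatic ring with 2 hetero atoms, one six-membered aromatic ring of carbon only) in place of a group of 11 heavy atoms (8 carbon, 1 nitrogen, 2 oxygen; one six-membered non-aromatic ring with 2 hetero atoms, one six-membered aromatic ring of carbon only), on an aromatic nitrogen. Among the measured compounds shown here, no step between measured compounds mirrors this change, so the step from compound 1 to compound 3 is expected to be small, a 1.3-fold lower number from compound 1 to compound 3 (0.10 log units; within the scatter), toward slightly stronger inhibition of growth at most. Compound 3 is therefore estimated at 12000 nM, within 5000 nM to 30000 nM.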

Compound 3, concentration for 50% growth inhibition: 10500 nM
Beside the measured number, compound 3's estimate is 1.1-fold (0.06 log units) above it; the range from low to high includes it.
By their numbers in this assay, from the lowest: compound 2; then compounds 3 and 1 (each within the scatter of the next).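

In this assay the group with a five-membered aromatic ring with 2 hetero atoms replaces the one with a six-membered non-aromatic ring with 2 hetero atoms, on an aromatic nitrogen, giving a 1.4-fold lower number from compound 1 to compound 3 (0.16 log units; within the scatter) and leaving no readable difference at this position. The exchange of these two ring groups, which match in hydrogen-bond donors and acceptors, therefore does not separate compound 3 from compound 1 here. No measurement accompanies this result that could explain it.

The compounds shown leave open whether a group carrying an amine or a carboxylic acid on this aromatic nitrogen would move the number beyond the scatter.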